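This account rests on a few compounds, and the source may have more. Where it says the series, first, only, none or still open, it means among the compounds named here.

Measured compounds:
compound 1 `O=C(Nc1cccc(-n2cc(-c3ccncc3)c(-c3ccc(Cl)c(O)c3)n2)c1)Nc1cccc(C(F)(F)F)c1` — 9580 nM
compound 2 `COc1cc(-c2nn(-c3cccc(NC(=O)Nc4cc(C(F)(F)F)cc(C(F)(F)F)c4)c3)cc2-c2ccncc2)ccc1Cl` — 1520 nM
compound 3 `COc1cc(-c2nn(-c3cccc(NC(=O)c4cccc(C(F)(F)F)c4)c3)cc2-c2ccncc2)ccc1Cl` — > 50000 nM

The read-out throughout is a functional assay on LOX IMVI cells (Homo sapiens) for inhibition, read by sulforhodamine B assay, with a stated time of 48 h; a higher number here means a weaker inhibitor of growth, a lower number a stronger inhibitor of growth. Compound 1 holds the highest of the two numbers given; compound 2 sits beyond the scatter on the lower side of it. Compound 3 reports only a limit, (the limit of > 50000 nM in this assay, at which 1 of the 3 values shown sits), and no number. Going by the values given here, no pair of these three compounds differs in one place only, so no single measured step is available; the gap between compound 1 and compound 2 spans both a change on the urea-bearing ring and a change on the core substituent, and cannot be split.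

Compound 4 `O=C(Nc1cccc(-n2cc(-c3ccncc3)c(-c3ccc(Cl)c(O)c3)n2)c1)Nc1ccc(Cl)c(Cl)c1` is not yet measured. Its difference from compound 1 is 3,4-dichlorophenyl in place of 3-(trifluoromethyl)phenyl on an amide-type nitrogen. Among the compounds with values here, with no measured step on this position, the expected step from compound 1 to compound 4 is set small, a 1.6-fold lower number from compound 1 to compound 4 (0.20 log units; within the scatter), toward a somewhat lower number but not clearly beyond the scatter. Compound 4 is therefore estimated at 6000 nM, within 2000 nM to 20000 nM.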

Compound 4, concentration for total growth inhibition: 3570 nM
Estimate against measurement, compound 4: 1.7-fold (0.23 log units) above; the measured number falls inside the stated range.
By their numbers in this assay, from the lowest: compound 2; then compound 4; then compound 1. At a limit, above all of these: compound 3.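

Going by these compounds alone, the amide-type nitrogen, whose other neighbour is the carbonyl carbon, now gives the first single-place reading of the series in this assay: 3,4-dichlorophenyl in place of 3-(trifluoromethyl)phenyl gives a 2.7-fold lower number from compound 1 to compound 4 (0.43 log units; beyond the scatter) with the rest of the structure unchanged. The aryl group at this position therefore affects growth inhibition in this cell assay, and between these two groups 3,4-dichlorophenyl gives the stronger inhibitor, though only by a modest step. No measured property of these compounds bears on this step.

From the compounds shown here alone, whether the same exchange carries over to the core of compound 2 remains open. Going by these compounds, it is also open how this nitrogen would respond to an aryl group bearing an amine or a carboxylic acid, or to a longer alkyl chain in place of the aryl group.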